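Compound 1 to compound 3: 4-fluorophenyl to 4-methylphenyl

A few compounds are considered here, and "the series" means these few. Any claim that something is new, unique, unknown or untested is made for them only; others in the source may bear on it.

In an ADME assay on HeLa cells (Homo sapiens) for cytotoxicity, read by MTT assay (on this read-out lower numbers stand for stronger inhibition and higher numbers for weaker inhibition), compound 1 (`COc1ccc(C[C@H]2COC(=O)[C@@H]2Cc2ccc(OCc3cn(-c4ccc(F)cc4)nn3)c(OC)c2)cc1OC`) gives >= 600000 nM, which is a limit of the assay and not a number. Compound 2 (`CCN1CCN(C(=O)CCC(=O)Oc2ccc(C[C@H]3C(=O)OC[C@@H]3Cc3ccc(OC)c(OC)c3)cc2OC)CC1`) gives 190000 nM. Compound 3 (`COc1ccc(C[C@H]2COC(=O)[C@@H]2Cc2ccc(OCc3cn(-c4ccc(C)cc4)nn3)c(OC)c2)cc1OC`) keeps the core of compound 1 and changes one place: methyl in place of fluoro on an aromatic carbon, para to a large group, turning 4-fluorophenyl into 4-methylphenyl (methyl in place of fluoro on an aromatic carbon). Among the measured compounds shown here, no measured step between compounds exists to size this change, so the expectation rests on the single swap. In this assay, no step beyond the scatter is expected, and the estimated at least 1.2-fold lower number from compound 1 to compound 3 (0.07 log units; that floor lies within the scatter) should be read that way. A reading reported only as a limit is also quite likely. Compound 3 is estimated at 500000 nM, with an expected range of 150000 nM to 800000 nM.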

Compound 3, half-maximal inhibitory concentration: >= 600000 nM
Compound 3: a limit, no number; the forecaster's own chance of this, stated with the estimate: 55%; at least 1.2-fold (0.07 log units) between middle value and limit.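

In this assay compound 1 and compound 3 both read as limits and not numbers, so no step can be read for 4-fluorophenyl to 4-methylphenyl: the limit of >= 600000 nM in this assay, at which 2 of the 3 values shown sit.

The compounds shown leave open whether this swap changes the read-out at all.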